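The compounds below may be only part of what the source reports. "The series", "measured", "known", "first", "only" and "open" are said of these compounds alone.

Measured so far:
- compound 1 `CC1=C(C(=O)OCC2CC2)C(c2ccoc2)NC(=O)N1`: 426 nM
- compound 2 `CC1=C(C(=O)OCC2CCC2)C(c2ccoc2)NC(=O)N1`: 739 nM
- compound 3 `CC1=C(C(=O)OCC2CC2)C(c2ccsc2)NC(=O)N1`: 724 nM

All three were run in an assay on membranes from HEK293 cells for displacement of a labelled ligand from adenosine receptor A2b (Homo sapiens), read by scintillation counting, with a stated time of 30 min; a higher number here means a weaker inhibitor, a lower number a stronger inhibitor. Compound 2 differs from compound 1 by cyclobutyl in place of cyclopropyl on a saturated chain carbon bound to an oxygen next to a carbonyl group, and the step is a 1.7-fold higher number from compound 1 to compound 2 (0.24 log units; within the scatter). Compound 3 differs from compound 1 in its core by thiophen-3-yl in place of furan-3-yl on a saturated ring carbon, giving a 1.7-fold higher number from compound 1 to compound 3 (0.23 log units; within the scatter). Compound 2 and compound 3 sit at values that are within the scatter of each other, so nothing separates them.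

Compound 4 `CC1=C(C(=O)OCC2CCC2)C(c2ccsc2)NC(=O)N1` has not been measured. It differs from compound 3 by cyclobutyl in place of cyclopropyl on a saturated chain carbon bound to an oxygen next to a carbonyl group. Going by the values given here, this is the same change as that from compound 1 to compound 2, the place being described in identical words, so the earlier step is the only guide. In this assay compound 4 is expected to give 1200 nM. The step expected from this estimate is a 1.7-fold higher number from compound 3 to compound 4 (0.22 log units; within the scatter), set beside a 1.7-fold higher number from compound 1 to compound 2 (0.24 log units; within the scatter) on which it rests, a step that itself lay within the scatter. Accordingly the expected range for compound 4 runs from 550 nM to 2600 nM.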

Compound 4, inhibition constant: 1040 nM
The estimate for compound 4 lay 1.2-fold (0.06 log units) above the measured number, within the range that was stated.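

Cyclobutyl in place of cyclopropyl gives a 1.4-fold higher number from compound 3 to compound 4 (0.16 log units; within the scatter) in this assay, and its two readings agree: the same change on two cores in this assay, a 1.7-fold higher number (0.24 log units; within the scatter) from compound 1 to compound 2 and a 1.4-fold higher number (0.16 log units; within the scatter) from compound 3 to compound 4, 1.2-fold (0.08 log units) apart, within the scatter of two such steps. Thiophen-3-yl in place of furan-3-yl gives a 1.4-fold higher number from compound 2 to compound 4 (0.15 log units; within the scatter), and the two readings of that change agree as well: the same change on two cores in this assay, a 1.7-fold higher number (0.23 log units; within the scatter) from compound 1 to compound 3 and a 1.4-fold higher number (0.15 log units; within the scatter) from compound 2 to compound 4, 1.2-fold (0.08 log units) apart, within the scatter of two such steps. Going by these compounds alone, all of these steps lie within the scatter, so the four compounds show only that nothing here departs from carrying each change unaltered from one core to the other; they do not show that either change has an effect of its own, and steps this small cannot be told apart from no step at all.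

Open, from the compounds shown here alone, is whether a step beyond the scatter would carry over in the same way, for instance with a longer chain or an amine in the place of cyclopropyl or cyclobutyl. Also open, going by these compounds, is whether the agreement would hold with a phenyl group in the place of furan-3-yl or thiophen-3-yl.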